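From compound 3 to compound 4 in a cytotoxicity test

The source may hold more compounds than are shown below. What is called first, only, known or untested is meant among the compounds shown, and "the series" means these compounds.

Compound 1 `Cc1cc(C)cc(S(=O)(=O)c2c(C(=O)NCC(=O)NCc3ccco3)[nH]c3ccc(Cl)cc23)c1`: in an ADME assay on MT4 cells (Homo sapiens) for cytotoxicity, read by MTT assay (on this read-out lower numbers stand for higher toxicity in this test and higher numbers for lower toxicity in this test), compound 1 gives > 50000 nM, which is a limit of the assay and not a number.
Compound 2 `Cc1cc(C)cc(S(=O)(=O)c2c(C(=O)NC(C)C(=O)NCc3ccncc3)[nH]c3ccc(Cl)cc23)c1`: compound 2 gives 19500 nM.
Compound 3 `Cc1cc(C)cc(S(=O)(=O)c2c(C(=O)NCC(=O)NC(C)c3ccncc3)[nH]c3ccc(Cl)cc23)c1`: compound 3 gives 47000 nM.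

Of the two numbers, compound 3 holds the higher one; its nearest neighbour is compound 2, with a 2.4-fold higher number from compound 2 to compound 3 (0.38 log units; beyond the scatter). Against compound 1 the picture is an at least 1.0-fold lower number from compound 1 to compound 3 (0.02 log units; that floor lies within the scatter), because compound 1 sits at the limit of > 50000 nM in this assay, at which 1 of the 3 values shown sits.

Compound 4 `Cc1cc(C)cc(S(=O)(=O)c2c(C(=O)NC(C)c3ccccc3F)[nH]c3ccc(Cl)cc23)c1` differs from compound 3 in one place: a group of 9 heavy atoms (8 carbon, 1 fluorine; one six-membered aromatic ring of carbon only) in place of a group of 12 heavy atoms (9 carbon, 2 nitrogen, 1 oxygen; one six-membered aromatic ring with 1 hetero atom), on an amide-type nitrogen. All measured steps concern the group on this same amide-type nitrogen: an at least 2.5-fold lower number from compound 1 to compound 2 (0.40 log units; beyond the scatter) and a 2.4-fold higher number from compound 2 to compound 3 (0.38 log units; beyond the scatter), while an at least 1.0-fold lower number from compound 1 to compound 3 (0.02 log units; that floor lies within the scatter). For the measured compounds named here, none of them exchanges a six-membered aromatic ring with 1 hetero atom for a six-membered aromatic ring of carbon only, nor a group of 12 heavy atoms for one of 9, so no measured step matches this change directly. What they do show is that exchanges at this nitrogen move the read-out by modest amounts in either direction. For compound 4 the expected step is therefore a 1.6-fold lower number from compound 3 to compound 4 (0.19 log units; within the scatter), a shift not expected to clear the scatter. Compound 4 is estimated at 30000 nM, with a range from 12000 nM to 80000 nM.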

Compound 4, half-maximal cytotoxic concentration: > 51500 nM
Compound 4 ended at the assay's limit; the forecaster's own chance of this, stated with the estimate: 35%; middle value at least 1.7-fold (0.23 log units) from the limit.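

In this assay compound 4 gives > 51500 nM, which is a limit of the assay and not a number. The exchange on the amide-type nitrogen, which brings in 1-(2-fluorophenyl)ethyl with its six-membered aromatic ring of carbon only, gives an at least 1.0-fold higher number from compound 3 to compound 4 (0.03 log units; that floor lies within the scatter), so a group without the ring nitrogen and the carbonyl cannot be told apart from compound 3 here, while it does stand clear of the lowest number in the set, with an at least 2.6-fold higher number from compound 2 to compound 4 (0.42 log units; beyond the scatter). The step between compound 1 and compound 4 cannot be read, because compound 4 stands at a limit, as compound 1 does: the limit of > 51500 nM in this assay, at which 1 of the 4 values shown sits.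

How far the read-out of compound 4 lies past its limit remains unknown, and no pair shown isolates the fluorine, so its share in this result is open. Going by these compounds, how a plain phenyl, or a chain ending in an amine or a carboxylic acid, on the same amide-type nitrogen would read in this assay also stays open.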